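The source may report more compounds than this note shows. Statements on the series, on what has been measured and on what is new or still open speak of the compounds shown alone.

In a functional assay on DU-145 cells (Homo sapiens) for cytotoxicity, in the presence of a further agent that is not named here (on this read-out lower numbers stand for stronger inhibition and higher numbers for weaker inhibition), compound 1 (`Clc1ccc(-c2cc(-c3ccsc3)nc(-c3ccccc3Cl)c2)o1`) gives 19300 nM and compound 2 (`Cc1cccc(-c2cc(-c3ccc(Cl)o3)cc(-c3ccsc3)n2)c1`) gives 17900 nM, while compound 3 (`Clc1ccc(-c2cc(-c3cccnc3)nc(-c3ccsc3)c2)o1`) gives 21600 nM on the same read-out. Compound 3 therefore stands level with both others, within the scatter.

The next step leads to compound 4 (`Clc1cccc(-c2cc(-c3ccc(Cl)o3)cc(-c3ccsc3)n2)c1`), with 3-chlorophenyl in place of pyridin-3-yl on an aromatic carbon. Among the compounds with values here, no compound carrying 3-chlorophenyl has been measured yet. The measured steps that bear on this change vary the same place: pyridin-3-yl in place of 2-chlorophenyl gives a 1.1-fold higher number from compound 1 to compound 3 (0.05 log units; within the scatter) and pyridin-3-yl in place of 3-methylphenyl gives a 1.2-fold higher number from compound 2 to compound 3 (0.08 log units; within the scatter), while the exchange of the two substituted phenyl groups gives a 1.1-fold lower number from compound 1 to compound 2 (0.03 log units; within the scatter) in the same read-out. All three steps lie within the scatter, and none of the three compounds goes against this flat picture.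

No step beyond the scatter is therefore expected in this assay, and the data set no firm direction. The estimate sits among the three measured values and means an expected 1.1-fold lower number from compound 3 to compound 4 (0.06 log units; within the scatter) as the step. For compound 4 the estimated value is 19000 nM (expected range 11500 nM to 31000 nM).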

Compound 4, half-maximal inhibitory concentration: 10400 nM
Compound 4: the middle estimate sits 1.8-fold (0.26 log units) above what was measured, outside the stated range (below it).
By their numbers in this assay, from the lowest: compounds 4, 2, 1 and 3 (each within the scatter of the next, the first and the last beyond it).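

In this assay, within the data shown here, this position now shows a step beyond the scatter, which no earlier pair showed: 3-chlorophenyl in place of pyridin-3-yl gives a modest change (a 2.1-fold lower number from compound 3 to compound 4 (0.32 log units; beyond the scatter)). Compound 4 separates only from compound 3, since chloro in place of methyl (a 1.7-fold lower number from compound 2 to compound 4 (0.24 log units; within the scatter)) and 3-chlorophenyl in place of 2-chlorophenyl (a 1.9-fold lower number from compound 1 to compound 4 (0.27 log units; within the scatter)) both stay within the scatter, so neither the exchange of methyl for chloro nor the shift of the chloro group on the phenyl ring can be read as a real change. No measurement at hand offers an explanation for the step that separates compound 4 from compound 3.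

The compounds shown leave open whether an unsubstituted phenyl group at this place would read with compound 3 or with compound 4, and so whether the step follows the ring nitrogen leaving or the chloro group entering. Also open, going by these compounds, is how an amine or a carboxylic acid on the phenyl ring would read, and whether the step holds once the 5-chlorofuran-2-yl and thiophen-3-yl groups, common to all four compounds, are exchanged.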